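Replacing a Fluorinated Aryl Ring with a Hydroxyphenyl Ring

The source may report more compounds than this note shows. Statements on the series, on what has been measured and on what is new or still open speak of the compounds shown alone.

Compound 1 `C(=N/c1sc2c(c1-c1nc3ccccc3s1)CCCC2)\c1ccccc1`: 71.1 ug/mL
Compound 2 `Fc1ccccc1/C=N/c1sc2c(c1-c1nc3ccccc3s1)CCCC2`: 319 ug/mL
Compound 3 `FC(F)(F)c1ccc(/C=N/c2sc3c(c2-c2nc4ccccc4s2)CCCC3)cc1`: 250 ug/mL

These three compounds share one core and differ only in the aryl group attached to the carbon with a double bond to nitrogen. All were tested in an ADME assay on cells (Rhabdomyosarcoma cell, Homo sapiens) for cytotoxicity, read by MTT assay, with a stated time of 72 h; on this read-out lower numbers stand for higher toxicity in this test and higher numbers for lower toxicity in this test. Compound 3 stands second highest of the three numbers; compound 2 is nearest, with a 1.3-fold lower number from compound 2 to compound 3 (0.11 log units; within the scatter), and compound 1 is furthest, with a 3.5-fold higher number from compound 1 to compound 3 (0.55 log units; beyond the scatter). The move from compound 1 to compound 2 shows a 4.5-fold higher number from compound 1 to compound 2 (0.65 log units; beyond the scatter), so both ring substituents tested so far gave higher numbers than the bare phenyl ring in this assay.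

Compound 4 `Oc1ccccc1/C=N/c1sc2c(c1-c1nc3ccccc3s1)CCCC2` is the next compound in the series. It differs from compound 3 in one place: 2-hydroxyphenyl in place of 4-(trifluoromethyl)phenyl on a carbon with a double bond to nitrogen. For the measured compounds named here, no measured step involves a hydroxyl group, so the steps from compound 1 to compound 2 and from compound 1 to compound 3 bear on it only loosely, by showing that a single ring substituent can shift the number modestly. Going by the values given here, with no direct precedent, the expected step in this assay from compound 3 to compound 4 is a 1.7-fold lower number from compound 3 to compound 4 (0.22 log units; within the scatter), not beyond the scatter. Compound 4 is therefore estimated at 150 ug/mL, with a range from 50 ug/mL to 450 ug/mL.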

Compound 4, half-maximal cytotoxic concentration: 42.4 ug/mL
Beside the measured number, compound 4's estimate is 3.5-fold (0.55 log units) above it; measured number below the stated range.
By their numbers in this assay, from the lowest: compounds 4 and 1 (each within the scatter of the next); then compounds 3 and 2 (each within the scatter of the next).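

In this assay, this position on the carbon with a double bond to nitrogen now shows that a ring substituent does not always move the number away from that of the bare phenyl ring: hydroxy in place of hydrogen gives only (a 1.7-fold lower number from compound 1 to compound 4 (0.22 log units; within the scatter)), which leaves compound 4 and compound 1 indistinguishable. The identity of the substituent clearly matters, as hydroxy in place of fluoro gives (a 7.5-fold lower number from compound 2 to compound 4 (0.88 log units; beyond the scatter)), and 2-hydroxyphenyl in place of 4-(trifluoromethyl)phenyl gives (a 5.9-fold lower number from compound 3 to compound 4 (0.77 log units; beyond the scatter)), so the higher numbers of compound 2 and compound 3 do not extend to every substituted ring tested here. Nothing available explains why the fluorinated rings and the hydroxyphenyl ring separate in this way.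

The compounds shown leave open whether the hydroxyl hydrogen matters to this result, which a methoxy group on the same aromatic carbon could help test. They also leave open whether other groups on that aromatic carbon, such as an amine or a carboxylic acid, would stay with compound 4 and compound 1 or join compound 2 and compound 3.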